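Piperazine aryl swap: 2-chlorophenyl analogue of compound 3

This account rests on a few compounds, and the source may have more. Where it says the series, first, only, none or still open, it means among the compounds named here.

Compound 3 `COc1cccc(N2CCN(Cn3nc(-c4ccc5c(c4)OCCO5)oc3=S)CC2)c1` is known in a functional assay on BGC-823 cells (Homo sapiens) for antiproliferative activity, read by MTT assay, with a stated time of 48 h (a higher number here means a weaker inhibitor, a lower number a stronger inhibitor), only as a limit; in this assay compound 3 gives > 50000 nM. Compound 1 `Fc1ccccc1N1CCN(Cn2nc(-c3ccc4c(c3)OCCO4)oc2=S)CC1` also stands at a limit, with > 50000 nM in this assay. Among the measured compounds shown here, compound 2 `COc1ccccc1N1CCN(Cn2nc(-c3ccc4c(c3)OCCO4)oc2=S)CC1` is the one member of the set with a number, giving 19500 nM in this assay. Two of the three values therefore sit at the limit of > 50000 nM in this assay, at which 2 of the 3 values shown sit.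

Compound 4 `S=c1oc(-c2ccc3c(c2)OCCO3)nn1CN1CCN(c2ccccc2Cl)CC1` is not yet measured. Relative to compound 3 the change is 2-chlorophenyl in place of 3-methoxyphenyl on an amine nitrogen in a ring. For the measured compounds named here, two measured steps bear on it. The step of an at least 2.5-fold higher number from compound 2 to compound 3 (0.40 log units; beyond the scatter) shows that 3-methoxyphenyl in place of 2-methoxyphenyl on the ring nitrogen costs at least a modest step. The step of an at least 2.5-fold lower number from compound 1 to compound 2 (0.40 log units; beyond the scatter) shows that methoxy in place of fluoro on the aromatic carbon gains at least a modest step. The step that the two limits leave unreadable from compound 1 to compound 3 cannot be read. Compound 4 carries a halogen on the phenyl, as compound 1 does, and compound 1 rests at the limit, so the expected step of an at least 1.2-fold lower number from compound 3 to compound 4 (0.09 log units; that floor lies within the scatter) is taken to stay near the limit rather than move beyond the scatter. Compound 4 is expected to give 40000 nM, within 15000 nM to 60000 nM, with a real chance that only a limit is reported.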

Compound 4, half-maximal inhibitory concentration: > 50000 nM
Compound 4 was reported as a limit; the forecaster's own chance of this, stated with the estimate: 55%; at least 1.2-fold (0.09 log units) between middle value and limit.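

Chloro in place of methoxy on the aromatic carbon gives an at least 2.5-fold higher number from compound 2 to compound 4 (0.40 log units; beyond the scatter) in this assay, so a second halogen now falls short of the methoxy of compound 2, where earlier only the fluoro of compound 1 did. In this assay compound 4 gives > 50000 nM, which is a limit, and the steps that link it to compound 1 and compound 3 cannot be read. Among the four aryl groups on the ring nitrogen, only the 2-methoxyphenyl of compound 2 gives a number, and methoxy alone does not account for this, since compound 3 also carries a methoxy and goes against any such reading, leaving the set with: the limit of > 50000 nM in this assay, at which 3 of the 4 values shown sit.

The limits leave open whether 2-chlorophenyl, 2-fluorophenyl and 3-methoxyphenyl differ from one another at all, as none of the three has a number. As far as these compounds go, it also remains open whether a 2-ethoxyphenyl or 2-hydroxyphenyl group on the ring nitrogen would give a lower number than the 2-methoxyphenyl of compound 2, or one that again stands at the limit.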